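Capping the hydroxy on compound 3: an ethyl ether

The compounds below may be only part of what the source reports. "The series", "measured", "known", "first", "only" and "open" are said of these compounds alone.

Measured in an assay on RBL-1 cells for inhibition of Polyunsaturated fatty acid 5-lipoxygenase (Rattus norvegicus); on this read-out higher numbers stand for weaker inhibition and lower numbers for stronger inhibition:
compound 1 `O=C(/C=C/c1ccc(O)c(O)c1)c1cccc(O)c1` 4.2 nM
compound 2 `Cc1ccc(C(=O)/C=C/c2ccc(O)c(O)c2)c(C)c1` 17 nM
compound 3 `O=C(/C=C/c1ccc(O)c(O)c1)c1cc(O)ccc1O` 64 nM

Compound 3 stands at the highest number of the three in this assay; compound 2 is nearest, compound 1 furthest. Within the data shown here, the only single-change step available is a 15-fold higher number from compound 1 to compound 3 (1.18 log units; beyond the scatter), a hydroxy on the ketone-bearing ring placed where compound 1 has hydrogen.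

Compound 4 `CCOc1ccc(O)c(C(=O)/C=C/c2ccc(O)c(O)c2)c1` differs from compound 3 by ethyl in place of hydrogen on an oxygen on an aromatic ring, so one hydroxy of the ketone-bearing ring becomes an ethoxy while the other hydroxy and the two hydroxy groups of the other ring stay.

Among the measured compounds shown here, no measured step bears on alkylation of a phenolic oxygen. For the measured compounds named here, the values of compound 1 and compound 2 show only that a ketone-bearing ring with a hydroxy and one with methyls instead of any hydroxy both sit well below compound 3, which gives no direction for capping a hydroxy. With nothing to anchor a direction, the expectation for compound 4 is a step of a 1.3-fold lower number from compound 3 to compound 4 (0.11 log units; within the scatter), inside the scatter, with a wide range.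

Compound 4 is therefore expected at about 50 nM in this assay, within 12 nM to 200 nM.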

Compound 4, half-maximal inhibitory concentration: 5.3 nM
The estimate for compound 4 lay 9.4-fold (0.97 log units) above the measured number, and the stated range ends above it.
By their numbers in this assay, from the lowest: compounds 1 and 4 (each within the scatter of the next); then compound 2; then compound 3.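

In this assay, placing ethyl on this oxygen of the ketone-bearing ring gives a 12-fold lower number from compound 3 to compound 4 (1.08 log units; beyond the scatter) and so shows that the hydrogen of this hydroxy is not needed for a low number on this read-out. The oxygen on the aromatic ring therefore tolerates an ethoxy in place of a hydroxy, with the other hydroxy of that ring and the two hydroxy groups of the other ring unchanged. Until now the only single-change step on this ring was a 15-fold higher number from compound 1 to compound 3 (1.18 log units; beyond the scatter) and it raised the number, so compound 4 adds the first single change shown to lower it, and the number on this read-out now proves sensitive in both directions, on the strength of these two steps alone.

Still open, going by these compounds, is whether the low number depends on ethyl itself or would hold with a methoxy, a longer chain such as butoxy, or a carboxylic acid carried on the same oxygen, and whether ethyl on the remaining hydroxy of that ring would act in the same way. Nothing in hand accounts for the size of this step.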